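Chloro to fluoro on the benzyl ring: compound 4

A few compounds are considered here, and "the series" means these few. Any claim that something is new, unique, unknown or untested is made for them only; others in the source may bear on it.

Measured so far in a functional assay on DU-145 cells (Homo sapiens) for inhibition, read by trypan blue exclusion, with a stated time of 96 h; a higher number here means a weaker inhibitor of growth, a lower number a stronger inhibitor of growth:
compound 1 `CSc1ccc(/C=C(\C(=O)c2ccc(Cl)cc2)S(=O)(=O)Cc2ccc(Cl)cc2)cc1` — 10000 nM
compound 2 `Cc1ccc(/C=C(\C(=O)c2ccc(Cl)cc2)S(=O)(=O)Cc2ccc(Cl)cc2)s1` — 1000 nM
compound 3 `COc1ccccc1/C=C(\C(=O)c1ccc(Cl)cc1)S(=O)(=O)Cc1ccc(Cl)cc1` — 25000 nM

Compound 2 stands lowest of the three numbers in this assay. Its steps to the others are both beyond the scatter: a 10-fold lower number from compound 1 to compound 2 (1.00 log units; beyond the scatter), and a 25-fold higher number from compound 2 to compound 3 (1.40 log units; beyond the scatter). The remaining pair also separates: a 2.5-fold higher number from compound 1 to compound 3 (0.40 log units; beyond the scatter).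

Compound 4 `Cc1ccc(/C=C(\C(=O)c2ccc(Cl)cc2)S(=O)(=O)Cc2ccc(F)cc2)s1` keeps the core of compound 2 and differs in one place: fluoro in place of chloro on an aromatic carbon. Going by the values given here, every measured step so far changes the aryl on the double-bonded chain carbon bound to a double-bonded chain carbon; none changes the ring carrying the chloro that leaves. Among the compounds with values here, no measured step bears on this change, so there is no number to weigh it by. The exchange of one halogen for another at this position is expected to leave the number within the scatter: a 1.2-fold higher number from compound 2 to compound 4 (0.08 log units; within the scatter) is the expected step. Compound 4 is therefore estimated at 1200 nM in this assay, with a range from 400 nM to 4000 nM.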

Compound 4, concentration for 50% growth inhibition: 50000 nM
Compound 4: middle estimate off by 42-fold (1.62 log units), on the low side, outside the stated range (above it).
By their numbers in this assay, from the lowest: compound 2; then compound 1; then compounds 3 and 4 (each within the scatter of the next).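

Going by these compounds alone, the benzyl ring, untouched by the earlier steps, is a sensitive position in this assay: 4-fluorobenzyl in place of 4-chlorobenzyl gives a 50-fold higher number from compound 2 to compound 4 (1.70 log units; beyond the scatter), a change of the same order as the largest aryl exchange, a 25-fold higher number from compound 2 to compound 3 (1.40 log units; beyond the scatter). On this core the two halogens are not interchangeable at this place, and chloro goes with the far lower number. Nothing at hand accounts for the size of this step.

A single exchange cannot show whether the loss is specific to fluoro or follows any departure from chloro; bromo, methyl or plain hydrogen on this ring would separate the two readings. Also open, on these data alone, is whether the same exchange behaves alike on the 4-chlorophenyl carrying the carbonyl, or with the 2-methoxyphenyl of compound 3 in place of the 5-methylthiophen-2-yl.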